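Aminoaryl ether in place of the pyrrolidinyl ether

The source may report more compounds than this note shows. Statements on the series, on what has been measured and on what is new or still open speak of the compounds shown alone.

Measured compounds:
compound 1 `Cc1ccc(NC(=O)c2cccc(C(F)(F)F)c2)cc1N1Cc2cnc(O[C@H]3CCN(C(=O)OC(C)(C)C)C3)nc2N(C)C1=O`, 30 nM
compound 2 `Cc1ccc(NC(=O)c2cccc(C(F)(F)F)c2)cc1N1Cc2cnc(O[C@H]3CCNC3)nc2N(C)C1=O`, 450 nM

Going by the values given here, in a functional assay on K562 cells (Homo sapiens) for antiproliferative activity, read by CellTiter-Glo and CCK-8 assay, with a stated time of 72 h (a higher number here means a weaker inhibitor of growth, a lower number a stronger inhibitor of growth), compound 2 gives 450 nM, the highest number of the two measured so far; its nearest neighbour is compound 1 at 30 nM. Among the compounds with values here, the only step recorded is a 15-fold higher number from compound 1 to compound 2 (1.18 log units; beyond the scatter), and it concerns a group on the ring nitrogen rather than the group that changes here. Compound 3 `Cc1ccc(Oc2ncc3c(n2)N(C)C(=O)N(c2cc(NC(=O)c4cccc(C(F)(F)F)c4)ccc2C)C3)cc1N` differs from compound 2 in one place: 3-amino-4-methylphenyl in place of pyrrolidin-3-yl on an oxygen on an aromatic ring. Within the data shown here, no measured step bears on this exchange, so the direction of the change in this assay is open. Compound 3 is therefore expected to land near compound 2, with a wide range, at an estimated 200 nM (range 25 nM to 1600 nM), which corresponds to an expected step of a 2.3-fold lower number from compound 2 to compound 3 (0.35 log units; beyond the scatter).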

Compound 3, concentration for 50% growth inhibition: 13 nM
Compound 3: middle estimate off by 15-fold (1.19 log units), on the high side; the whole stated range lies above it.
By their numbers in this assay, from the lowest: compound 3; then compound 1; then compound 2.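

Going by these compounds alone, at this oxygen on an aromatic ring, the earlier compounds showed only that a pyrrolidine ring gave a lower number with tert-butoxycarbonyl on its nitrogen than without it. The exchange of pyrrolidin-3-yl for 3-amino-4-methylphenyl gives a 35-fold lower number from compound 2 to compound 3 (1.54 log units; beyond the scatter) in this assay, so this place accepts a six-membered aromatic ring in place of the non-aromatic one, and the free ring amine of compound 2 is not matched by the aromatic amine of compound 3. The same exchange against the protected ring gives a 2.3-fold lower number from compound 1 to compound 3 (0.36 log units; beyond the scatter), a modest step, and nothing measured here explains either step.

As far as these compounds go, it remains open whether the amine or the methyl on the new ring carries the gain. A plain phenyl, or an acetamide in place of the amine, would separate these two groups.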